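From a Ketone Side Chain to Its Oxime Ether

The source may report more compounds than this note shows. Statements on the series, on what has been measured and on what is new or still open speak of the compounds shown alone.

Measured compounds:
compound 1, `COc1c(N2CCN(CC#N)C(C)C2)c(F)cc2c(=O)c(C(=O)O)cn(C3CC3)c12`, gives 354 ug/mL in an ADME assay on Vero cells (Chlorocebus sabaeus) for cytotoxicity, read by MTT assay, with a stated time of 72 h; a lower number here means that less compound is tolerated, a higher number that more compound is tolerated;
compound 2, `COC(=O)CN1CCN(c2c(F)cc3c(=O)c(C(=O)O)cn(C4CC4)c3c2OC)CC1C`, gives 500 ug/mL;
compound 3, `COc1c(N2CCN(CCC(C)=O)C(C)C2)c(F)cc2c(=O)c(C(=O)O)cn(C3CC3)c12`, gives 9.84 ug/mL.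

Compound 3 stands lowest of the three numbers: a 36-fold lower number from compound 1 to compound 3 (1.56 log units; beyond the scatter) and a 51-fold lower number from compound 2 to compound 3 (1.71 log units; beyond the scatter), both large, whereas a 1.4-fold higher number from compound 1 to compound 2 (0.15 log units; within the scatter). Compound 4, `CO/N=C(\C)CCN1CCN(c2c(F)cc3c(=O)c(C(=O)O)cn(C4CC4)c3c2OC)CC1C`, differs from compound 3 in one place: a group of 5 heavy atoms (3 carbon, 1 nitrogen, 1 oxygen; no ring) in place of a group of 3 heavy atoms (2 carbon, 1 oxygen; no ring), on a saturated chain carbon, two bonds along the chain from an amine nitrogen in a ring. For the measured compounds named here, no measured step covers this exact change; the two large steps show only that the 2-oxopropyl group lies far below the cyano and methoxycarbonyl groups in this assay. Compound 4 is therefore expected to move part of the way back, to about 60 ug/mL, within a wide range of 15 ug/mL to 300 ug/mL. That estimate means an expected 6.1-fold higher number from compound 3 to compound 4 (0.79 log units; beyond the scatter).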

Compound 4, half-maximal cytotoxic concentration: 157 ug/mL
Compound 4: the middle estimate sits 2.6-fold (0.42 log units) below what was measured, within the range that was stated.
By their numbers in this assay, from the lowest: compound 3; then compound 4; then compounds 1 and 2 (each within the scatter of the next).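

In this assay, the ketone's low number proves to depend on the acetyl end rather than on the chain that carries it: with the chain kept, the oxime ether gives a 16-fold higher number from compound 3 to compound 4 (1.20 log units; beyond the scatter). The recovery remains incomplete, with a 3.2-fold lower number from compound 2 to compound 4 (0.50 log units; beyond the scatter) and a 2.3-fold lower number from compound 1 to compound 4 (0.35 log units; beyond the scatter), both modest beside that large step. Nothing shown here accounts for these steps. As far as these compounds go, it remains open whether a free oxime, an alcohol in place of the acetyl, or a longer chain ending in the same oxime ether would stand nearer compound 4 or compound 3.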